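The compounds below may be only part of what the source reports. "The series", "measured", "known", "first", "only" and "open" are said of these compounds alone.

In a functional assay on Bel-7402 cells (Homo sapiens) for antiproliferative activity, with a stated time of 72 h (on this read-out lower numbers stand for stronger inhibition and higher numbers for weaker inhibition), compound 3 `CCN(CC)Cc1c(OC)cc(OC)c(C(=O)/C=C/c2ccccc2Cl)c1O` gives 6700 nM and compound 1 `COc1cc(OC)c(C(=O)/C=C/c2ccccc2Cl)c(O)c1CN1CCCC1` gives 6800 nM, two values within the scatter of each other. Compound 2 `COc1cc(OC)c(C(=O)/C=C/c2ccccc2Cl)c(O)c1CN(C)CC(=O)O` stands apart from both at 35200 nM and so forms the far end of this small set. The next structure is compound 4 `COc1cc(OC)c(C(=O)/C=C/c2ccccc2Cl)c(O)c1CN(C)CCCN(C)C`, which keeps the shared core and alters only the amine on a saturated chain carbon bound to an aromatic carbon, as follows: (3-(dimethylamino)propyl)(methyl)amino in place of diethylamino on a saturated chain carbon bound to an aromatic carbon. Within the data shown here, two measured steps bear on this. Exchanging pyrrolidin-1-yl for diethylamino gave a 1.0-fold lower number from compound 1 to compound 3 (0.01 log units; within the scatter), while exchanging (carboxymethyl)(methyl)amino for diethylamino gave a 5.3-fold lower number from compound 2 to compound 3 (0.72 log units; beyond the scatter). Among the measured compounds shown here, the entering group has no carboxymethyl, so the closer guide is the step with 6800 nM for compound 1 at its start, although no measured compound carries so long a chain. The expected change is therefore a 1.2-fold lower number from compound 3 to compound 4 (0.09 log units; within the scatter), which would be no step beyond the scatter. For compound 4 the estimated value is 5500 nM, with an expected range from 2200 nM to 14000 nM in this read-out.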

Compound 4, half-maximal inhibitory concentration: 30900 nM
For compound 4 the middle estimate is 5.6-fold (0.75 log units) below the measured one, and the stated range ends below it.
By their numbers in this assay, from the lowest: compounds 3 and 1 (each within the scatter of the next); then compounds 4 and 2 (each within the scatter of the next).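

In this assay, pyrrolidin-1-yl and diethylamino had not separated at this position, on a saturated chain carbon bound to an aromatic carbon, but the longer diamine chain did: (3-(dimethylamino)propyl)(methyl)amino gave a 4.6-fold higher number from compound 3 to compound 4 (0.66 log units; beyond the scatter) and also a 4.5-fold higher number from compound 1 to compound 4 (0.66 log units; beyond the scatter). A number as high as that of the carboxymethyl compound therefore does not require a carboxy group, since 2-(dimethylamino)ethyl in place of carboxy gave only a 1.1-fold lower number from compound 2 to compound 4 (0.06 log units; within the scatter). No measurement shown here accounts for this rise.

The compounds shown leave open whether the rise goes with the second amine nitrogen or with the length of the chain. A propyl(methyl)amino group, which lacks the terminal dimethylamino, and a (2-(dimethylamino)ethyl)(methyl)amino group, with its shorter chain, would help to separate the two.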